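The source may report more compounds than this note shows. Statements on the series, on what has been measured and on what is new or still open speak of the compounds shown alone.

Measured compounds:
Compound 1 `N#CC1=C(N)Oc2c(c3nc4ccccc4nc3c3ccccc23)C12C(=O)N(Cc1cnnn1-c1ccccc1Br)c1ccccc12`: in a functional assay on A549 cells (Homo sapiens) for antiproliferative activity, read by MTT assay, with a stated time of 48 h (on this read-out lower numbers stand for stronger inhibition and higher numbers for weaker inhibition), compound 1 gives > 50000 nM, which is a limit of the assay and not a number.
Compound 2 `N#CC1=C(N)Oc2c(c3nc4ccccc4nc3c3ccccc23)C12C(=O)N(Cc1cnnn1-c1cccc(Br)c1)c1ccccc12`: in this assay compound 2 gives > 50000 nM, again a limit rather than a number.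
Among the compounds with values here, compound 3 `N#CC1=C(N)Oc2c(N)cc3nc4ccccc4nc3c2C12C(=O)N(Cc1cnnn1-c1cccc(Br)c1)c1ccccc12`: in this assay compound 3 gives 18900 nM, the only number among the three.

Compound 1 and compound 2 share one core, and compound 3 has a different core; how the two cores differ is not broken down here. On the core of compound 2, the change from compound 2 to compound 1 is 2-bromophenyl in place of 3-bromophenyl on an aromatic nitrogen, and its step that the two limits leave unreadable from compound 2 to compound 1 cannot be read because both values sit at the limit of > 50000 nM in this assay, at which 2 of the 3 values shown sit. Compound 4 `N#CC1=C(N)Oc2c(N)cc3nc4ccccc4nc3c2C12C(=O)N(Cc1cnnn1-c1ccccc1Br)c1ccccc12`, not yet measured, applies the same change to compound 3: 2-bromophenyl in place of 3-bromophenyl on an aromatic nitrogen. The measured instance gives no readable size. The step is expected to be small, a 1.1-fold higher number from compound 3 to compound 4 (0.02 log units; within the scatter), resting only on compound 3 at 18900 nM. Compound 4 is therefore expected to give about 20000 nM, between 7000 nM and 50000 nM.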

Compound 4, half-maximal inhibitory concentration: 27400 nM
The estimate for compound 4 lay 1.4-fold (0.14 log units) below the measured number; measured number inside the range.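

On the core of compound 3, putting 2-bromophenyl in place of 3-bromophenyl on an aromatic nitrogen gives a 1.4-fold higher number from compound 3 to compound 4 (0.16 log units; within the scatter) in this assay, so the two bromophenyl groups cannot be told apart on this core. The same change on the core of compound 2 cannot be read, because compound 1 and compound 2 both give a limit of the assay and not a number: the limit of > 50000 nM in this assay, at which 2 of the 4 values shown sit. This means that the small size of the step is seen on one core only, and the series neither confirms nor refutes that it carries over to the other core.

The compounds shown leave open what other groups would do in this place. A plain phenyl, a benzyl group or a longer alkyl chain on that nitrogen could still give a step beyond the scatter.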